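Swapping Carboxy for Chloro on a Shared Core

The source may report more compounds than this note shows. Statements on the series, on what has been measured and on what is new or still open speak of the compounds shown alone.

Of the compounds shown here, three built on one shared core have been tested in an ADME assay on microsomes from liver (Homo sapiens) for metabolic stability, using NADPH, with a stated time of 60 min, in the presence of a further agent that is not named here; on this read-out lower numbers stand for slow clearance and higher numbers for fast clearance. Among the compounds with values here, compound 1 `CC(=O)NC1C2CC3CC1CC(C2)C31OO[C@]2(CC[C@@H](c3ccc(OCC(=O)O)cc3)CC2)O1` is the only one with a plain number: in this assay compound 1 gives 10 mL.min-1.g-1. Compound 2 `CC(C)(Oc1ccc([C@H]2CC[C@]3(CC2)OOC2(O3)C3CC4CC(C3)CC2C4)cc1)C(=O)O` sits at a limit of the assay rather than at a number: in this assay compound 2 gives < 7 mL.min-1.g-1. Compound 3 `O=C(O)COc1ccc([C@H]2CC[C@]3(CC2)OOC2(O3)C3CC4CC(C3)CC2C4)cc1C(=O)O` also sits at a limit of the assay: in this assay compound 3 gives < 7 mL.min-1.g-1. Within the data shown here, compound 3 therefore stands at the limit of < 7 mL.min-1.g-1 in this assay, at which 2 of the 3 values shown sit, the slow end of what has been seen, and no step between measured compounds can be drawn from these three.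

Compound 4 `O=C(O)COc1ccc([C@H]2CC[C@]3(CC2)OOC2(O3)C3CC4CC(C3)CC2C4)cc1Cl` is not yet measured. It differs from compound 3 in one place: chloro in place of carboxy on an aromatic carbon. The leaving group carries the one hydrogen-bond donor and one acceptor counted there; the entering chloro carries none. Among the measured compounds shown here, with no measured step to lean on, the expected step in this assay is small, toward faster clearance if at all, and is estimated as an at least 1.4-fold higher number from compound 3 to compound 4 (0.15 log units; that floor lies within the scatter). Compound 4 is thus expected to give about 10 mL.min-1.g-1, most likely between 5 mL.min-1.g-1 and 25 mL.min-1.g-1, and it may well again land only at a limit.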

Compound 4, intrinsic clearance in microsomes: < 7 mL.min-1.g-1
Compound 4 ended at the assay's limit; the forecaster's own chance of this, stated with the estimate: 40%; at least 1.4-fold (0.15 log units) between middle value and limit.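

Compound 3 and compound 4 both sit at a limit of this assay rather than at a number, so no step from one to the other can be read: the limit of < 7 mL.min-1.g-1 in this assay, at which 3 of the 4 values shown sit.

The compounds shown leave open whether chloro in place of carboxy on the aromatic carbon changes clearance at all.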